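Removing the tert-butyl group from compound 3

A few compounds are considered here, and "the series" means these few. Any claim that something is new, unique, unknown or untested is made for them only; others in the source may bear on it.

Of the compounds shown here, three built on a shared core have been measured in a functional assay on PC-3 cells (Homo sapiens) for cytotoxicity, read by sulforhodamine B assay, tested at 10 uM; on this read-out lower numbers stand for less inhibition and higher numbers for more inhibition at the one concentration tested (going by the name of the read-out). Compound 1 `CC(=O)OC[C@H]1O[C@@H](n2cc(-c3cc(-c4ccccc4)no3)c(=O)[nH]c2=O)C[C@@H]1OC(C)=O` gives 85.5%, compound 2 `CC(=O)OC[C@H]1O[C@@H](n2cc(-c3cc(C)no3)c(=O)[nH]c2=O)C[C@@H]1OC(C)=O` gives 92.4%, and compound 3 `CC(C)(C)c1ccc(Cn2cc(-c3cn([C@H]4C[C@H](O)[C@@H](CO)O4)c(=O)[nH]c3=O)nn2)cc1` gives 92.3%. Compound 3 sits close to both of its companions: its number and that of compound 2 are within the scatter of each other, and the gap to compound 1 is within the scatter as well, so the three cannot be ranked on these data.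

Compound 4 `O=c1[nH]c(=O)n([C@H]2C[C@H](O)[C@@H](CO)O2)cc1-c1cn(Cc2ccccc2)nn1` differs from compound 3 in one place: hydrogen in place of tert-butyl on an aromatic carbon. Among the measured compounds shown here, only one measured step gives any guidance. The change a number 6.9 percentage points higher from compound 1 to compound 2 (within the scatter) also replaced one aromatic substituent by a smaller one, and it stayed within the scatter. The change from compound 3 to compound 4 is of a similar kind, a large hydrocarbon group shrinking to a hydrogen on an aromatic ring, so no movement beyond the scatter is expected in this assay, and the direction cannot be called from the data at hand.

Compound 4 is therefore expected to give about 89%, with a plausible range from 75% to 100%, which corresponds to an estimated step of a number 3.3 percentage points lower from compound 3 to compound 4 (within the scatter).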

Compound 4, a percentage reported as inhibition, at one concentration (the size of the read-out at that concentration, not a potency): 92.1%
Compound 4: the middle estimate sits 3.1 percentage points below what was measured; the measured number falls inside the stated range.
By their numbers in this assay, from the lowest: compounds 1, 4, 3 and 2 (each within the scatter of the next).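

Going from the 4-(tert-butyl)phenyl of compound 3 to the plain phenyl of compound 4 gives, in this assay, a number 0.2 percentage points lower from compound 3 to compound 4 (within the scatter), so at this place on the six-membered aromatic ring the tert-butyl group can be removed with no difference that stands out from the scatter. The earlier compounds shown here offered only a number 6.9 percentage points higher from compound 1 to compound 2 (within the scatter), a swap of methyl for phenyl on another part of a differently built compound, and they said nothing about this position. What the new pair adds is that the unsubstituted phenyl keeps the number in the same range as the tert-butyl compound, although nothing at hand gives a reason for this result.

Whether an amine, a carboxylic acid or a longer chain at this place on the ring would also leave the number in that range remains open, since tert-butyl and hydrogen are the only two groups shown there. Both numbers also come from a single concentration, so they give the size of the read-out at that concentration and leave open whether compound 3 and compound 4 would differ in potency.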